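The compounds below may be only part of what the source reports. "The series", "measured", "known", "first", "only" and "open" are said of these compounds alone.

For the measured compounds named here, compound 3 `COc1cc(Cl)cc(-c2nn(-c3cccc(NC(=O)Nc4cc(C(F)(F)F)cc(C(F)(F)F)c4)c3)cc2-c2ccncc2)c1` gives -38.1% in a functional assay on SK-MEL-2 cells (Homo sapiens) for inhibition, read by sulforhodamine B assay, with a stated time of 48 h, tested at 10 uM (a lower number here means a stronger effect, a higher number a weaker effect of the compound at the concentration tested), the lowest of the three numbers measured so far. Compound 1 `O=C(Nc1cccc(-n2cc(-c3ccncc3)c(-c3cc(O)cc(Cl)c3)n2)c1)Nc1ccc(Cl)c(C(F)(F)F)c1` gives -38%, and compound 2 `COc1cc(Cl)cc(-c2nn(-c3cccc(NC(=O)Nc4ccc(Cl)c(C(F)(F)F)c4)c3)cc2-c2ccncc2)c1` gives -34%; both of these lie within the scatter of the value for compound 3. Compound 4 `COc1cc(Cl)cc(-c2nn(-c3cccc(NC(=O)Nc4cccc(C(F)(F)F)c4)c3)cc2-c2ccncc2)c1` differs from compound 3 by hydrogen in place of trifluoromethyl on an aromatic carbon. Going by the values given here, the only measured single step, a number 4 percentage points higher from compound 1 to compound 2 (within the scatter), concerns a methyl in place of hydrogen on an oxygen on an aromatic ring and does not bear on this change; no measured step touches a trifluoromethyl at all. The analyst therefore expects in this assay no step beyond the scatter, a number 2.1 percentage points higher from compound 3 to compound 4 (within the scatter). For compound 4 the analyst estimates -36%, with a range from -58% to -14%.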

Compound 4, a percentage reported as activity, at one concentration (the size of the read-out at that concentration, not a potency): -36.7%
Beside the measured number, compound 4's estimate is 0.7 percentage points above it, within the range that was stated.
By their numbers in this assay, from the lowest: compounds 3, 1, 4 and 2 (each within the scatter of the next).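

Hydrogen in place of trifluoromethyl on this aromatic carbon gives a number 1.4 percentage points higher from compound 3 to compound 4 (within the scatter) in this assay, and hydrogen in place of chloro gives a number 2.7 percentage points lower from compound 2 to compound 4 (within the scatter). For the compounds shown here, two different groups on this ring can thus give way to hydrogen without the read-out at the concentration tested moving beyond the scatter, which no earlier step could show. Nothing at hand explains this result. On these data alone, whether an amine or a carboxylic acid on that ring would move the number beyond the scatter stays open. So does the effect of removing the remaining trifluoromethyl.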